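The compounds below may be only part of what the source reports. "The series", "measured", "known", "first", "only" and "open" are said of these compounds alone.

- compound 1 `COc1ccc(CN(C(=O)CSC(=S)N2CCCc3cc(OC)ccc32)c2cc(OC)c(OC)c(OC)c2)cc1`: 5530 nM
- compound 2 `COc1cc(N(Cc2ccc(Cl)cc2)C(=O)CSC(=S)N2CCN(C(=O)OC(C)(C)C)CC2)cc(OC)c1OC`: 11900 nM

In a functional assay on KYSE-450 cells (Homo sapiens) for inhibition, read by CCK-8 assay, with a stated time of 48 h (on this read-out higher numbers stand for weaker inhibition and lower numbers for stronger inhibition), compound 2 gives 11900 nM, the higher of the two numbers, so it is the weaker inhibitor of the pair, and the gap to compound 1 lies beyond the scatter. These two compounds differ in more than one place, so their gap cannot be pinned on any single change.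

The next compound to be tested is compound 3 `COc1ccc(CN(C(=O)CSC(=S)N2CCN(C(=O)OC(C)(C)C)CC2)c2cc(OC)c(OC)c(OC)c2)cc1[N+](=O)[O-]`. It keeps everything in compound 2 except one group: 4-methoxy-3-nitrophenyl in place of 4-chlorophenyl on a saturated chain carbon bound to an amide-type nitrogen, which amounts to 4-methoxy-3-nitrophenyl in place of 4-chlorophenyl on a saturated chain carbon bound to an amide-type nitrogen. Within the data shown here, no measured pair isolates a change of this kind, so the forecast in this assay is loose. A small step is expected, perhaps toward a lower number, and it may well stay within the scatter. The expected change is a 1.3-fold lower number from compound 2 to compound 3 (0.12 log units; within the scatter). For compound 3 the estimated value is 9000 nM, with an expected range from 3500 nM to 25000 nM.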

Compound 3, half-maximal inhibitory concentration: 810 nM
For compound 3 the middle estimate is 11-fold (1.05 log units) above the measured one, outside the stated range (below it).
By their numbers in this assay, from the lowest: compound 3; then compound 1; then compound 2.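

In this assay, the change to 4-methoxy-3-nitrophenyl gives a 15-fold lower number from compound 2 to compound 3 (1.17 log units; beyond the scatter), so the group on this saturated chain carbon bound to an amide-type nitrogen can move the number far beyond the scatter. Compound 1 and compound 2 differ in more than one place and could not show this, whereas this single exchange ties a large gain in inhibition to this one place, with the larger group, which carries hydrogen-bond acceptors where 4-chlorophenyl has none, giving the lower number. No measurement shown here explains why the step is so large.

Which part of the entering group matters remains open: compound 1 has a methoxy-bearing ring at this place but also differs elsewhere, so it cannot separate the methoxy from the nitro group. Also unresolved is whether a phenyl ring bearing only the nitro group, or one with an amine or a nitrile in the nitro group's place, would keep the lower number, and whether the same exchange would have a similar effect on the core of compound 1.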